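Chloro to fluoro on the aryl ring of compound 3

The compounds below may be only part of what the source reports. "The series", "measured", "known", "first", "only" and "open" are said of these compounds alone.

Within the data shown here, in an assay on isolated protein for inhibition of Amine oxidase [flavin-containing] A (Bos taurus) (a lower number here means a stronger inhibitor, a higher number a weaker inhibitor), compound 3 `CCC(=O)N1N=C(c2ccc(OC)cc2)CC1c1ccc(Cl)cc1` gives 832 nM, the lowest of the three numbers so far. Compound 1 `CCC(=O)N1N=C(c2ccccc2)CC1c1ccc(F)cc1` gives 7240 nM and compound 2 `CCC(=O)N1N=C(c2ccc(OC)cc2)CC1c1ccccc1` gives 63100 nM. Among the measured compounds shown here, the one single-point step among them, a 76-fold lower number from compound 2 to compound 3 (1.88 log units; beyond the scatter), is large. Compound 4 `CCC(=O)N1N=C(c2ccc(OC)cc2)CC1c1ccc(F)cc1` differs from compound 3 by fluoro in place of chloro on an aromatic carbon. For the measured compounds named here, no measured pair shows this exact exchange; compound 1 also carries a fluoro but lacks the methoxy group, and its value only shows it standing between compound 2 and compound 3. Because the gain from hydrogen to chloro in a 76-fold lower number from compound 2 to compound 3 (1.88 log units; beyond the scatter) was large, part of it is expected to be lost with the smaller halogen. Compound 4 is therefore expected at 2500 nM (range 800 nM to 8000 nM). The expected step is a 3.0-fold higher number from compound 3 to compound 4 (0.48 log units; beyond the scatter).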

Compound 4, half-maximal inhibitory concentration: 1000 nM
Compound 4: middle estimate off by 2.5-fold (0.40 log units), on the high side, within the range that was stated.
By their numbers in this assay, from the lowest: compounds 3 and 4 (each within the scatter of the next); then compound 1; then compound 2.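

In this assay, chloro and fluoro at this position read alike on the methoxy-bearing core (a 1.2-fold higher number from compound 3 to compound 4 (0.08 log units; within the scatter)). The large step from hydrogen is therefore not specific to chloro, since fluoro gives it too (a 63-fold lower number from compound 2 to compound 4 (1.80 log units; beyond the scatter)). With the 4-fluorophenyl held constant, methoxy in place of hydrogen adds a smaller, modest step (a 7.2-fold lower number from compound 1 to compound 4 (0.86 log units; beyond the scatter)).

No measurement on hand explains why the two halogens match. From the compounds shown here alone, whether bromo, trifluoromethyl or an amine at this position would keep the step from hydrogen remains open.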